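A New Group on the Carbonyl Carbon

The source may report more compounds than this note shows. Statements on the series, on what has been measured and on what is new or still open speak of the compounds shown alone.

In a functional assay on Caco-2 cells (Homo sapiens) for antiproliferative activity, read by MTT assay, with a stated time of 48 h (on this read-out higher numbers stand for weaker inhibition and lower numbers for stronger inhibition), compound 1 (`CCN(CC)CCNC(=O)c1ccc(C(CC)(CC)c2ccc(OCCC(O)(CC)CC)c(C)c2)n1CC`) gives 1630 nM. Compound 2 (`C#CC(C)OC(=O)c1ccc(C(CC)(CC)c2ccc(OCCC(O)(CC)CC)c(C)c2)n1CC`) gives > 50000 nM, which is a limit of the assay and not a number. On the numbers shown, compound 2 stands at the limit of > 50000 nM in this assay, at which 1 of the 2 values shown sits.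

Compound 3 (`CCOC(=O)CN(C)C(=O)c1ccc(C(CC)(CC)c2ccc(OCCC(O)(CC)CC)c(C)c2)n1CC`) keeps the shared core but carries ((ethoxycarbonyl)methyl)(methyl)amino in place of (1-methylprop-2-yn-1-yl)oxy on a carbonyl carbon. Among the measured compounds shown here, only one measured step bears on this position. That step, an at least 30-fold higher number from compound 1 to compound 2 (1.48 log units; beyond the scatter), is large and beyond the scatter, and it came with the loss of (2-(diethylamino)ethyl)amino from the same carbonyl carbon. Compound 3 lacks that group too, so it is expected to resemble compound 2 in this assay rather than compound 1. One step is thin evidence, and the limit hides how far compound 2 actually lies from any measurable number. The expected change is small, if any, and is estimated as an at least 1.2-fold lower number from compound 2 to compound 3 (0.09 log units; that floor lies within the scatter). For compound 3 the estimate is 40000 nM, with an expected range of 12000 nM to 50000 nM.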

Compound 3, half-maximal inhibitory concentration: 30300 nM
Estimate against measurement, compound 3: 1.3-fold (0.12 log units) above; measured number inside the range.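

With compound 3, this assay gives a measured number for a compound without (2-(diethylamino)ethyl)amino on the carbonyl carbon, and here a nitrogen stays attached to that carbon, so the large loss does not require the oxygen link of compound 2: the replacement brings a 19-fold higher number from compound 1 to compound 3 (1.27 log units; beyond the scatter). The value of compound 2, > 50000 nM, is a limit of the assay and not a number. Read against that limit, the new group gives an at least 1.6-fold lower number from compound 2 to compound 3 (0.21 log units; that floor lies within the scatter), so the data do not separate the (1-methylprop-2-yn-1-yl)oxy and ((ethoxycarbonyl)methyl)(methyl)amino groups beyond the scatter.

Compound 3 differs from compound 1 at both ends of the group on the carbonyl carbon, since it has neither the amide hydrogen nor the diethylamino end, so the compounds shown cannot tell which of these features goes with the lower number of compound 1. A simple ethylamino group would keep the amide hydrogen without the diethylamino end, while (3-(diethylamino)propyl)amino, a longer chain, would test how far that end can sit from the carbonyl carbon.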